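Replacing the sulfur-linked group of compound 3 with a heteroaromatic ring

The source may hold more compounds than are shown below. What is called first, only, known or untested is meant among the compounds shown, and "the series" means these compounds.

Measured compounds:
compound 1 `Cc1nc(S(C)(=O)=O)ccc1Oc1ncnc(OC2CCN(C(=O)OC(C)(C)CF)CC2)c1F` gives 95%
compound 2 `Cc1nc(S(C)(=O)=O)ccc1Oc1ncnc(OC2CCN(C(=O)SC(C)C)CC2)c1F` gives 81%
compound 3 `Cc1nc(S(C)(=O)=O)ccc1Oc1ncnc(OC2CCN(C(=O)SC3(C)CC3)CC2)c1F` gives 77%

In a functional assay on isolated protein for inhibition of Glucose-dependent insulinotropic receptor (Rattus norvegicus), read by HTRF and cAMP accumulation (a lower number here means a smaller maximal response, a higher number a larger maximal response), compound 3 stands lowest of the three; its nearest neighbour is compound 2, within the scatter, and its furthest is compound 1, beyond it. Compound 4 `Cc1nc(S(C)(=O)=O)ccc1Oc1ncnc(OC2CCN(C(=O)c3nc(C(C)(C)F)no3)CC2)c1F` is not yet measured. It differs from compound 3 at the carbonyl carbon whose other neighbour is the amide-type nitrogen in a ring: a group of 9 heavy atoms (5 carbon, 2 nitrogen, 1 oxygen, 1 fluorine; one five-membered aromatic ring with 3 hetero atoms) in place of a group of 5 heavy atoms (4 carbon, 1 sulfur; one three-membered non-aromatic ring of carbon only), on a carbonyl carbon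

Within the data shown here, two measured steps touch this same carbonyl carbon. The step of a number 14 percentage points lower from compound 1 to compound 2 (beyond the scatter) and the step of a number 18 percentage points lower from compound 1 to compound 3 (beyond the scatter) both lowered the maximal response modestly, while a number 4 percentage points lower from compound 2 to compound 3 (within the scatter) stayed within the scatter. Among the measured compounds shown here, no measured compound carries a five-membered aromatic ring at this position, so the direction of the new step is uncertain. Given that the changes so far at this carbon moved the value by modest amounts, compound 4 is expected to shift by a number 8 percentage points higher from compound 3 to compound 4 (within the scatter). Compound 4 is therefore estimated at 85%, between 65% and 105%.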

Compound 4, largest response reached (reported as efficacy), in percent of the reference or control that the assay uses: 84%
For compound 4 the middle estimate is 1 percentage points above the measured one, within the range that was stated.
By their numbers in this assay, from the lowest: compounds 3, 2 and 4 (each within the scatter of the next); then compound 1.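

In this assay, a five-membered aromatic ring with 3 hetero atoms on the carbonyl carbon reads much like the sulfur-linked groups, with a number 7 percentage points higher from compound 3 to compound 4 (within the scatter) and a number 3 percentage points higher from compound 2 to compound 4 (within the scatter), so this position accepts a much larger, ring-bearing group with no loss of maximal response beyond the scatter. The ring does not match the group of compound 1, however: the step is a number 11 percentage points lower from compound 1 to compound 4 (beyond the scatter), and so all three replacements shown for that group, the two sulfur-linked ones and this ring, give lower numbers than compound 1. Nothing at hand accounts for this result.

From the compounds shown here alone, what a methyl or a cyclopropyl group in place of the fluorine-bearing substituent on the ring would do remains open. So does whether a phenyl ring on the carbonyl carbon would behave like this one.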